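A few compounds are considered here, and "the series" means these few. Any claim that something is new, unique, unknown or untested is made for them only; others in the source may bear on it.

Compound 2 `CC(=O)NCc1ccccc1-c1ccc(COC2CC[C@H](N3CCCCCC3)[C@H]2OC/C=C\CCC(=O)O)cc1` was tested in a functional assay for antagonist activity at thromboxane A2 receptor (Rattus norvegicus) (a lower number here means tighter binding, a higher number weaker binding), where compound 2 gives 126 nM. That is the higher of the two single numbers available here: compound 3 `O=C(O)CC/C=C\CO[C@H]1[C@@H](OCc2ccc(-c3ccccc3CO)cc2)CC[C@@H]1N1CCCCCC1` gives 12.6 nM in this assay, a gap beyond the usual scatter. Compound 1 `O=C(O)CC/C=C\CO[C@H]1[C@@H](OCc2ccc(-c3ccccc3)cc2)CC[C@@H]1N1CCCCC1` has two entries in this assay, 31.6 nM; 50.1 nM (2 entries) (the several entries of compound 1 in this assay, 31.6 nM; 50.1 nM (2 entries)). Compound 4 `CS(=O)(=O)Nc1ccccc1-c1ccc(COC2CC[C@H](N3CCCCCC3)[C@H]2OC/C=C\CCC(=O)O)cc1` differs from compound 2 in one place: methanesulfonamido in place of acetamidomethyl on an aromatic carbon. Going by the values given here, no pair of measured compounds shares that change, so only an expectation can be offered. The step of a 2.0-fold lower number from compound 2 to compound 4 (0.30 log units; within the scatter) is expected to be small, toward a lower number, and hardly beyond the scatter. For compound 4 in this assay the estimate is 63 nM, with a range from 20 nM to 250 nM.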

Compound 4, dissociation constant: 3.98 nM
Compound 4: middle estimate off by 16-fold (1.20 log units), on the high side; the whole stated range lies above it.
By their numbers in this assay, from the lowest: compound 4; then compound 3; then compound 2.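

Placing methanesulfonamido in place of acetamidomethyl on this aromatic carbon gives a 32-fold lower number from compound 2 to compound 4 (1.50 log units; beyond the scatter) in this assay. Going by these compounds alone, the earlier compounds offered no pair differing in one place, so this is the first sign that the group here strongly affects the measured number, even though the two groups have the same heavy-atom count. Nothing measured here accounts for the size of this step.

Still open, from the compounds shown here alone, is whether the sulfonyl or the removal of the methylene link matters more, which acetamido on the same carbon would help separate. Going by these compounds, how a carboxylic acid would behave at this position also remains unknown.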